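Butylamino in place of hexyloxy on the shared core

This account rests on a few compounds, and the source may have more. Where it says the series, first, only, none or still open, it means among the compounds named here.

In an ADME assay on Akata cells (Homo sapiens) for cytotoxicity, with a stated time of 7 days (on this read-out higher numbers stand for lower toxicity in this test and lower numbers for higher toxicity in this test), compound 1 (`CN(C)c1nc(N)nc2c1ncn2/C=C1/CC1(CO)CO`) returns > 24000 nM as a limit, not a number. Compound 2 (`CCCSc1nc(N)nc2c1ncn2/C=C1/CC1(CO)CO`) returns > 20000 nM as a limit too. Compound 3 (`CCCCCCOc1nc(N)nc2c1ncn2/C=C1/CC1(CO)CO`) likewise returns > 20000 nM as a limit. Where compound 3 stands among them cannot be read. Compound 4 (`CCCCNc1nc(N)nc2c1ncn2/C=C1/CC1(CO)CO`) has butylamino in place of hexyloxy on an aromatic carbon. Bearing on this are a step that the two limits leave unreadable from compound 1 to compound 2 and a step that the two limits leave unreadable from compound 1 to compound 3 and also a step that the two limits leave unreadable from compound 2 to compound 3 with no size to carry over. No step beyond the scatter is therefore expected in this assay for this change. An estimated a number no higher from compound 3 to compound 4 (the limit leaves the size open) is what is expected here. Compound 4 is estimated at 20000 nM within an expected range from 9000 nM to 45000 nM in this test.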

Compound 4, half-maximal cytotoxic concentration: > 24000 nM
Compound 4 ended at the assay's limit; the forecaster's own chance of this, stated with the estimate: 80%; middle value at least 1.2-fold (0.07 log units) away from the limit.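

In this assay, among the compounds shown here, compound 4 gave only a limit, as did compound 1, compound 2 and compound 3, and no step among the four can be read. The compounds shown leave open whether these groups differ in cytotoxicity at all.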